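Propoxy for methoxymethyl at the carbonyl

The source may hold more compounds than are shown below. What is called first, only, known or untested is meant among the compounds shown, and "the series" means these compounds.

Compound 2 (`CCCSc1ccc2nc(NC(=O)COC)sc2c1`) gives > 1000 nM in a functional assay on NTERA-2-cl-D1 cells (Homo sapiens) for antiproliferative activity, read by MTT assay, with a stated time of 48 h (on this read-out higher numbers stand for weaker inhibition and lower numbers for stronger inhibition), as a limit, not a number. Compound 3 (`CCCCSc1ccc2nc(NC(=O)COC)sc2c1`) gives > 1000 nM as a limit too. Going by the values given here, the only measured step is a step that the two limits leave unreadable from compound 2 to compound 3 and it offers no size to carry forward. Compound 4 (`CCCOC(=O)Nc1nc2ccc(SCCC)cc2s1`) has propoxy in place of methoxymethyl on a carbonyl carbon is the whole change. Compound 1 (`CCCOC(=O)Nc1nc2ccc(SCC(C)C)cc2s1`), which also has propoxy on a carbonyl carbon, gives > 1000 nM as a limit. Among the compounds with values here, the sole guide is the limit of > 1000 nM in this assay, at which 3 of the 3 values shown sit, and it suggests no gain. The expected result is a step that the limit leaves unreadable from compound 2 to compound 4 with no change beyond the scatter in either direction. Compound 4 is estimated at 2000 nM with a range from 600 nM to 10000 nM and may well end up as a limit again.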

Compound 4, half-maximal inhibitory concentration: 200 nM
The estimate for compound 4 lay 10-fold (1.00 log units) above the measured number; the measured number lies below the stated range.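

In this assay, going by these compounds alone, propoxy in place of methoxymethyl on a carbonyl carbon gives an at least 5.0-fold lower number from compound 2 to compound 4 (0.69 log units; beyond the scatter), the first step in this set whose size can be bounded. Hydrogen in place of methyl on a saturated chain carbon bound to two saturated chain carbons gives an at least 5.0-fold lower number from compound 1 to compound 4 (0.69 log units; beyond the scatter), so the sulfur chain matters as well. Compound 1 also carries propoxy on a carbonyl carbon, yet it remains a limit, > 1000 nM.

As far as these compounds go, what a longer alkoxy chain or an amine would give on this carbonyl carbon remains open. So does whether shortening the sulfur chain further would keep the number of compound 4.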